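This account rests on a few compounds, and the source may have more. Where it says the series, first, only, none or still open, it means among the compounds named here.

Measured in a functional assay on U-87MG ATCC cells (Homo sapiens) for antiproliferative activity; a higher number here means a weaker inhibitor, a lower number a stronger inhibitor:
- compound 1 `Cc1c2c(n3c1CCN(C(=O)[C@@H](N)C(C)C)C[C@@H](C)[C@H](C)Nc1cc-3ccc1C(N)=O)CC(C)(C)CC2=O`: 48 nM
- compound 2 `Cc1c2c(n3c1CCN(C(=O)C(C)(C)N)C[C@@H](C)[C@H](C)Nc1cc-3ccc1C(N)=O)CC(C)(C)CC2=O`: 39 nM
- compound 3 `Cc1c2c(n3c1CCN(C(=O)[C@H](C)O)C[C@@H](C)[C@H](C)Nc1cc-3ccc1C(N)=O)CC(C)(C)CC2=O`: 88 nM

Two steps fix the position of compound 3. The first is a 1.8-fold higher number from compound 1 to compound 3 (0.26 log units; within the scatter), and the second is a 2.3-fold higher number from compound 2 to compound 3 (0.35 log units; beyond the scatter). It therefore sits within the scatter of one amino neighbour and modestly beyond the scatter of the other.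

The next analogue is compound 4 `Cc1c2c(n3c1CCN(C(=O)[C@@H](O)C(C)C)C[C@@H](C)[C@H](C)Nc1cc-3ccc1C(N)=O)CC(C)(C)CC2=O`. The change is isopropyl in place of methyl on a saturated chain carbon bound to a carbonyl carbon and an oxygen on a saturated carbon. The same difference reads 1-hydroxyethyl to 1-hydroxy-2-methylpropyl.

Going by the values given here, no measured step isolates this change. The closest evidence is a 1.8-fold higher number from compound 1 to compound 3 (0.26 log units; within the scatter), where the swap to 1-hydroxyethyl from 1-amino-2-methylpropyl alters the group in two ways at once. A second, looser comparison is a 1.2-fold lower number from compound 1 to compound 2 (0.09 log units; within the scatter), which exchanges 1-amino-2-methylpropyl for 1-amino-1-methylethyl. Both steps are small, so neither supports a large move in this assay. Compound 4 shares its branched carbon skeleton with compound 1 and its hydroxyl with compound 3, so a value near or between those two is the reasonable expectation.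

The expected step is a 1.3-fold lower number from compound 3 to compound 4 (0.10 log units; within the scatter), a slight drop at most and nothing clearly beyond the scatter. The estimated value for compound 4 is 70 nM, with an expected range of 32 nM to 150 nM.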

Compound 4, half-maximal inhibitory concentration: 76 nM
Beside the measured number, compound 4's estimate is 1.1-fold (0.04 log units) below it; low and high end bracket the measured number.
By their numbers in this assay, from the lowest: compounds 2, 1, 4 and 3 (each within the scatter of the next, the first and the last beyond it).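

In this assay, going by these compounds alone, a 1.2-fold lower number from compound 3 to compound 4 (0.06 log units; within the scatter) is the first step that isolates isopropyl in place of methyl on a saturated chain carbon bound to a carbonyl carbon and an oxygen on a saturated carbon, and it shows that the hydroxy side chain accepts this larger group without a separation beyond the scatter. Within the data shown here, with the isopropyl held constant, a 1.6-fold higher number from compound 1 to compound 4 (0.20 log units; within the scatter) gives the first clean reading of hydroxy in place of amino, also within the scatter, whereas the earlier comparison of compound 1 with compound 3 changed two features at once. The comparison with the gem-dimethyl amino analogue, a 1.9-fold higher number from compound 2 to compound 4 (0.29 log units; within the scatter), also stays within the scatter, so compound 4 lacks the separation from compound 2 that compound 3 showed, though the two hydroxy compounds themselves remain within the scatter of each other.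

As far as these compounds go, how a longer chain, a cyclohexyl group or a carboxylic acid at this carbon would read in this assay stays open. The data at hand offer no explanation for any of these small steps.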